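Swapping the para substituent on the thioether phenyl ring

The source may hold more compounds than are shown below. What is called first, only, known or untested is meant among the compounds shown, and "the series" means these compounds.

Three nucleoside thioethers sharing one core have been tested in an assay on isolated protein for binding affinity to Equilibrative nucleoside transporter 1 (Homo sapiens); a higher number here means a weaker inhibitor, a lower number a stronger inhibitor. Compound 1 `OC[C@H]1O[C@@H](n2cnc3c(CSc4ccccc4Br)ncnc32)[C@H](O)[C@@H]1O` gives 2400 nM. Compound 2 `OC[C@H]1O[C@@H](n2cnc3c(CSc4c(F)cccc4Cl)ncnc32)[C@H](O)[C@@H]1O` gives 1510 nM, and the change from 2-bromophenyl to 2-chloro-6-fluorophenyl, a 1.6-fold lower number from compound 1 to compound 2 (0.20 log units; within the scatter), stays within the scatter. Compound 3 `N#Cc1ccc(SCc2ncnc3c2ncn3[C@@H]2O[C@H](CO)[C@@H](O)[C@H]2O)cc1` gives 81.3 nM, the lowest of the three numbers; the steps of a 30-fold lower number from compound 1 to compound 3 (1.47 log units; beyond the scatter) and a 19-fold lower number from compound 2 to compound 3 (1.27 log units; beyond the scatter) are both large and beyond the scatter.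

Compound 4 `COc1ccc(SCc2ncnc3c2ncn3[C@@H]2O[C@H](CO)[C@@H](O)[C@H]2O)cc1` differs from compound 3 by one change: methoxy in place of cyano on an aromatic carbon. Within the data shown here, no measured step touches this position directly. Among the measured compounds shown here, the two large steps to compound 3 both exchange a halogenated ring bearing substituents on other positions for 4-cyanophenyl, so they show only that the 4-cyanophenyl ring stands apart from compounds 1 and 2, not what another group para to the large group would do. The expectation for compound 4 therefore rests on little, and a moderate weakening with a wide range is the cautious guess. Compound 4 is estimated at 160 nM, with a range from 40 nM to 650 nM. That estimate corresponds to a step of a 2.0-fold higher number from compound 3 to compound 4 (0.29 log units; within the scatter), an expected loss that could still fall within the scatter.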

Compound 4, half-maximal inhibitory concentration: 617 nM
For compound 4 the middle estimate is 3.9-fold (0.59 log units) below the measured one; the range from low to high includes it.
By their numbers in this assay, from the lowest: compound 3; then compound 4; then compounds 2 and 1 (each within the scatter of the next).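

Among these compounds, at this position the group matters in this assay: a 7.6-fold higher number from compound 3 to compound 4 (0.88 log units; beyond the scatter) is the first step that changes only the group on the aromatic carbon para to a large group, and it lies beyond the scatter even though cyano and methoxy have the same count of heavy atoms and of hydrogen-bond acceptors. Loss of the cyano group does not remove the whole advantage over the halogenated rings, since a 2.4-fold lower number from compound 2 to compound 4 (0.39 log units; beyond the scatter) and a 3.9-fold lower number from compound 1 to compound 4 (0.59 log units; beyond the scatter) are both modest steps beyond the scatter, and among these four compounds the 4-cyanophenyl and 4-methoxyphenyl rings both give lower numbers than the two halogenated rings, with no compound going against this. No measurement at hand explains the order of these groups.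

On these data alone, it remains open how an amine, a carboxylic acid or a longer alkoxy chain on the same aromatic carbon would compare with cyano and methoxy. The place of a substituent also remains unseparated from its identity, as compound 1 and compound 2 differ from compound 3 and compound 4 in both.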